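Nitro to Trifluoromethyl on an Aromatic Ester Group

A few compounds are considered here, and "the series" means these few. Any claim that something is new, unique, unknown or untested is made for them only; others in the source may bear on it.

Three esters built on a shared core have been tested in a functional assay on MCF7 cells (Homo sapiens) for antiproliferative activity, read by MTT assay, with a stated time of 72 h; a lower number here means a stronger inhibitor, a higher number a weaker inhibitor. Compound 1 `CC1=CC[C@H]2[C@H](CC[C@]2(C)O)C(C)(C)[C@@H]1CC[C@H]1[C@]2(C)CC[C@H](OC(=O)c3ccc([N+](=O)[O-])cc3)C(C)(C)O[C@H]2CC[C@@]1(C)O` gives 21600 nM. Compound 2 `CC1=CC[C@H]2[C@H](CC[C@]2(C)O)C(C)(C)[C@@H]1CC[C@H]1[C@]2(C)CC[C@H](OC(=O)c3ccc(C(F)(F)F)cc3)C(C)(C)O[C@H]2CC[C@@]1(C)O` gives 23400 nM. Compound 3 `CC1=CC[C@H]2[C@H](CC[C@]2(C)O)C(C)(C)[C@@H]1CC[C@H]1[C@]2(C)CC[C@H](OC(=O)c3cccc([N+](=O)[O-])c3)C(C)(C)O[C@H]2CC[C@@]1(C)O` gives 36000 nM. Compound 4 `CC1=CC[C@H]2[C@H](CC[C@]2(C)O)C(C)(C)[C@@H]1CC[C@H]1[C@]2(C)CC[C@H](OC(=O)c3cccc(C(F)(F)F)c3)C(C)(C)O[C@H]2CC[C@@]1(C)O` has not yet been measured. Compound 3 differs from compound 1 by 3-nitrophenyl in place of 4-nitrophenyl on a carbonyl carbon. The change from compound 3 to compound 4 is trifluoromethyl in place of nitro on an aromatic carbon. The same kind of change, (trifluoromethyl in place of nitro on an aromatic carbon), runs from compound 1 to compound 2, with the difference that there the group is para to a large group, whereas in compound 4 it is meta to a large group. That earlier step, a 1.1-fold higher number from compound 1 to compound 2 (0.03 log units; within the scatter), was small. Because a 1.1-fold higher number from compound 1 to compound 2 (0.03 log units; within the scatter) was so small, the step to compound 4 is expected to be small as well, about a 1.1-fold higher number from compound 3 to compound 4 (0.02 log units; within the scatter). Compound 4 is therefore estimated at 38000 nM, most likely between 20000 nM and 75000 nM.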

Compound 4, half-maximal inhibitory concentration: 37900 nM
Compound 4: the middle estimate sits 1.0-fold (0.00 log units) above what was measured; measured number inside the range.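

In this assay, trifluoromethyl in place of nitro gives a 1.1-fold higher number from compound 3 to compound 4 (0.02 log units; within the scatter), and the change behaves alike whether it starts from the 4-nitrophenyl or the 3-nitrophenyl ester: the same change on two cores in this assay, a 1.1-fold higher number (0.03 log units; within the scatter) from compound 1 to compound 2 and a 1.1-fold higher number (0.02 log units; within the scatter) from compound 3 to compound 4, 1.0-fold (0.01 log units) apart, within the scatter of two such steps

The other new steps, a 1.6-fold higher number from compound 2 to compound 4 (0.21 log units; within the scatter) and a 1.8-fold higher number from compound 1 to compound 4 (0.24 log units; within the scatter), are also within the scatter, and this assay does not separate these compounds. The two pairs show that this exchange carried across with no readable effect, but they do not show that a larger effect would carry across the same way, and they give no reason for the match.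

Still open, on these data alone, is whether an amine or a carboxylic acid on the same aromatic ring would move the number beyond the scatter. As far as these compounds go, whether a nitrile would do so is equally open.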